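A hydroxy group on a compound sitting at the limit

The compounds below may be only part of what the source reports. "The series", "measured", "known", "first", "only" and "open" are said of these compounds alone.

Values in a functional assay on SMMC-7721 cells (Homo sapiens) for antiproliferative activity, read by MTT assay, with a stated time of 72 h (a higher number here means a weaker inhibitor, a lower number a stronger inhibitor), are as follows.

compound 1 `COc1cc(/C=N/NC(=S)N2CCOCC2)cc(OC)c1OC` gives > 64000 nM
compound 2 `C/C(=N\NC(=S)N1CCOCC1)c1ccccc1` gives > 64000 nM
compound 3 `C/C(=N\NC(=S)N1CCOCC1)c1ccccc1O` gives > 64000 nM

All three entries are limits of the assay and not numbers. For the measured compounds named here, compound 2 therefore has no number as a starting point, and its only reading is the limit > 64000 nM for this compound. Going by the values given here, the same holds across the whole set, which rests on the limit of > 64000 nM in this assay, at which 3 of the 3 values shown sit, and gives no ranking among the compounds.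

Compound 4 `C/C(=N\NC(=S)N1CCOCC1)c1cccc(O)c1` has not yet been measured. It differs from compound 2 by hydroxy in place of hydrogen on an aromatic carbon, meta to a large group, as counted here: hydroxy in place of hydrogen on an aromatic carbon.

Among the compounds with values here, one measured step bears on this change, since compound 3 carries the same kind of exchange: a step that the two limits leave unreadable from compound 2 to compound 3. That step has no readable size, so it supplies no measured shift in either direction. Compound 3 remains at the limit > 64000 nM after its exchange.

No step beyond the scatter is therefore expected in this assay, and no direction is favoured. The expected outcome is a number no higher from compound 2 to compound 4 (the limit leaves the size open) on this estimate. For compound 4 the estimated value is 64000 nM with an expected range from 30000 nM to 130000 nM and a report as a limit is the likeliest result.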

Compound 4, half-maximal inhibitory concentration: > 64000 nM
Compound 4: a limit, no number; the forecaster's own chance of this, stated with the estimate: 85%; the middle value lies on the limit itself.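

No step can be read from compound 2 to compound 4, since both entries are limits of the assay and not numbers: the limit of > 64000 nM in this assay, at which 4 of the 4 values shown sit. The compounds shown leave open how the four rank in this assay, and whether hydroxy in place of hydrogen on an aromatic carbon shifts the value at all.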